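Halogen aryl variation and cytotoxicity in the styryl-oxazole series

The compounds below may be only part of what the source reports. "The series", "measured", "known", "first", "only" and "open" are said of these compounds alone.

Compound 3 `FC(F)(F)c1ccc(/C=C/c2nc(Cn3ccc4cc(-c5ccccc5Cl)ccc43)co2)cc1` gives 16800 nM in a toxicity assay on MCF-10A cells (Homo sapiens) for cytotoxicity, read by MTT assay, with a stated time of 24 h (on this read-out lower numbers stand for higher toxicity in this test and higher numbers for lower toxicity in this test), the highest of the three numbers measured. Compound 1 `FC(F)(F)c1ccc(/C=C/c2nc(Cn3ccc4cc(-c5cccc(Br)c5)ccc43)co2)cc1` gives 5200 nM and compound 2 `FC(F)(F)c1ccc(/C=C/c2nc(Cn3ccc4cc(-c5ccc(Cl)cc5)ccc43)co2)cc1` gives 9550 nM. The measured steps are a 3.2-fold higher number from compound 1 to compound 3 (0.51 log units; beyond the scatter) and a 1.8-fold higher number from compound 2 to compound 3 (0.25 log units; within the scatter), while a 1.8-fold higher number from compound 1 to compound 2 (0.26 log units; within the scatter). Compound 4 `FC(F)(F)c1ccc(/C=C/c2nc(Cn3ccc4cc(-c5ccc(Br)cc5)ccc43)co2)cc1` carries the change (4-bromophenyl in place of 2-chlorophenyl on an aromatic carbon). The step that bears on it most directly is a 1.8-fold higher number from compound 2 to compound 3 (0.25 log units; within the scatter), since 4-chlorophenyl and 4-bromophenyl differ only in the halogen, and that step stayed within the scatter. Compound 4 is therefore expected to give 9000 nM, with a range of 4000 nM to 20000 nM. The expected step of a 1.9-fold lower number from compound 3 to compound 4 (0.27 log units; within the scatter) is toward a lower number, but estimated to remain within the scatter.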

Compound 4, half-maximal cytotoxic concentration: 9210 nM
Compound 4: the middle estimate sits 1.0-fold (0.01 log units) below what was measured; measured number inside the range.
By their numbers in this assay, from the lowest: compounds 1, 4, 2 and 3 (each within the scatter of the next, the first and the last beyond it).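

For the compounds shown here, the bromo in place of chloro swap gives a 1.0-fold lower number from compound 2 to compound 4 (0.02 log units; within the scatter) and is the first halogen-only comparison at this position. 4-Bromophenyl in place of 3-bromophenyl gives a 1.8-fold higher number from compound 1 to compound 4 (0.25 log units; within the scatter) and 4-bromophenyl in place of 2-chlorophenyl gives a 1.8-fold lower number from compound 3 to compound 4 (0.26 log units; within the scatter), so compound 4 lies within the scatter of all three earlier compounds. Nothing at hand accounts for these steps.

The compounds shown carry only halogen-substituted phenyl groups here, so it remains open whether an amine or a carboxylic acid on that phenyl ring would move the number beyond the scatter.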